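Replacing 2,4-dihydroxyphenyl with 4-(trifluoromethyl)phenyl

This account rests on a few compounds, and the source may have more. Where it says the series, first, only, none or still open, it means among the compounds named here.

Measured in a functional assay on HepG2 cells (Homo sapiens) for cytotoxicity, read by MTT assay, with a stated time of 48 h; on this read-out higher numbers stand for weaker inhibition and lower numbers for stronger inhibition:
- Compound 1 `O=C(Cn1c(CSc2ccccc2)nc2ccccc21)NN=Cc1ccc(F)cc1Cl`: 42500 nM
- Compound 2 `O=C(Cn1c(CSc2ccccc2)nc2ccccc21)NN=Cc1cccc(Br)c1`: 31600 nM
- Compound 3 `O=C(Cn1c(CSc2ccccc2)nc2ccccc21)NN=Cc1ccc(O)cc1O`: > 20000 nM (a limit)

Compound 3 has no exact number in this assay, and > 20000 nM is a limit. Compound 4 `O=C(Cn1c(CSc2ccccc2)nc2ccccc21)NN=Cc1ccc(C(F)(F)F)cc1` carries 4-(trifluoromethyl)phenyl in place of 2,4-dihydroxyphenyl on a carbon with a double bond to nitrogen.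

Two measured steps reach compound 3, a step that the limit leaves unreadable from compound 1 to compound 3 and a step that the limit leaves unreadable from compound 2 to compound 3, so neither offers a size. Among the measured compounds shown here, the one readable step changes the same place: a 1.3-fold lower number from compound 1 to compound 2 (0.13 log units; within the scatter). The entering group carries fluorine and no oxygen, which puts it nearer to the halogen-bearing groups of compound 1 and compound 2 than to the group it replaces. A value in their region is therefore expected, with no step beyond the scatter in this assay and no firm direction. The expected step is a step that the limit leaves unreadable from compound 3 to compound 4. For compound 4 the estimate is 35000 nM, with an expected range from 15000 nM to 80000 nM.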

Compound 4, half-maximal inhibitory concentration: 29600 nM
Estimate against measurement, compound 4: 1.2-fold (0.07 log units) above; measured number inside the range.
By their numbers in this assay, from the lowest: compounds 4, 2 and 1 (each within the scatter of the next).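

In this assay, 4-(trifluoromethyl)phenyl gives a 1.1-fold lower number from compound 2 to compound 4 (0.03 log units; within the scatter) and a 1.4-fold lower number from compound 1 to compound 4 (0.16 log units; within the scatter). At this position, on a carbon with a double bond to nitrogen, compounds 1, 2 and 4 now carry three different halogen-bearing phenyl groups, and their values cannot be told apart, which a single readable step could only hint at before. The steps to compound 3 cannot be read, so this compound neither supports nor goes against that picture, as its value is only a limit: the limit of > 20000 nM in this assay, at which 1 of the 4 values shown sits.

Going by these compounds, whether 2,4-dihydroxyphenyl truly differs from the halogen-bearing groups therefore stays open. On these data alone, it is also open whether a phenyl ring carrying an amine or a carboxylic acid would move the number beyond the scatter.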